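Title: A tetrazole on the quinoline core of compound 3

The source may hold more compounds than are shown below. What is called first, only, known or untested is meant among the compounds shown, and "the series" means these compounds.

Compound 3 `O=C(c1ccc(F)c(O)c1)c1ccc2ccccc2n1` is examined in an assay for inhibition of 17-beta-hydroxysteroid dehydrogenase type 1 (Homo sapiens), read by HPLC, with a stated time of 10 min, tested at 1 uM (on this read-out higher numbers stand for more inhibition at the one concentration tested (going by the name of the read-out) and lower numbers for less inhibition), where compound 3 gives 6%. On the numbers shown, compound 3 stands lowest of the two reported figures; its nearest neighbour is compound 1 `Cc1cc(-c2ccc3ccc(C(=O)c4ccc(F)c(O)c4)nc3c2)ccc1O`, which in this assay gives 11%, and the step of a number 5 percentage points lower from compound 1 to compound 3 (within the scatter) is small. Compound 2 `N#Cc1ccc2ccc(C(=O)c3ccc(F)c(O)c3)nc2c1` carries a nitrile at the same place and in this assay is reported as "not active" (no number reported), so no number is available for it.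

Compound 4 `O=C(c1ccc(F)c(O)c1)c1ccc2ccc(-c3nnn[nH]3)cc2n1` is not yet measured. It differs from compound 3 in one place: 1H-tetrazol-5-yl in place of hydrogen on an aromatic carbon. Among the measured compounds shown here, the only measured step that bears on this change is the one from compound 1 to compound 3, which lies within the scatter, and compound 2 shows that a small group at the same place can leave no measurable inhibition. No step beyond the scatter is therefore expected in this assay; the estimated step is a number 1 percentage points higher from compound 3 to compound 4 (within the scatter). Compound 4 is expected to give 7%, in a range from 0% to 20%.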

Compound 4, a percentage reported as inhibition, at one concentration (the size of the read-out at that concentration, not a potency) in the 17-beta-hydroxysteroid dehydrogenase type 1 assay: "not active" (no number reported)
The entry for compound 4 holds no number, and the estimate cannot be compared.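

Among the compounds shown here, compound 4 is reported as "not active" in the 17-beta-hydroxysteroid dehydrogenase type 1 assay, so no new step from compound 3 to compound 4 can be read there. In a physicochemical assay for solubility, in phosphate buffer, with a stated time of 24 h, at pH 7.4, tested at 200 uM (on this read-out higher numbers stand for higher solubility and lower numbers for lower solubility), compound 3 gives > 200000 nM, which is a limit of the assay and not a number. In the physicochemical assay compound 4 gives 50000 nM, which amounts to an at least 4.0-fold lower number from compound 3 to compound 4 (0.60 log units; beyond the scatter). The compounds shown leave open whether any group at this place on the shared core changes inhibition beyond the scatter in the 17-beta-hydroxysteroid dehydrogenase type 1 assay.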